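Azido to methylsulfanyl on the cyclopropane-fused core: toxicity notes

The source may report more compounds than this note shows. Statements on the series, on what has been measured and on what is new or still open speak of the compounds shown alone.

Compound 1 `CC(C)[C@@H](Nc1nc(Cl)nc2c1ncn2[C@H]1[C@H](O)[C@H](O)[C@]2(CN=[N+]=[N-])C[C@H]12)C1CC1` is read in an ADME assay on Vero 76 cells (Chlorocebus sabaeus) for cytotoxicity, read by neutral red uptake; on this read-out lower numbers stand for higher toxicity in this test and higher numbers for lower toxicity in this test; there compound 1 gives 32000 nM. Compound 2 `O[C@@H]1[C@H](O)[C@@H]2C[C@@H]2[C@H]1n1cnc2c(NC(C3CCC3)C3CCC3)nc(Cl)nc21` gives 17000 nM in this assay, and the two numbers for compound 1 and compound 2 sit within the scatter of each other, so neither can be set apart. Compound 3 `OC[C@H]1O[C@@H](n2cnc3c(NC(C4CCC4)C4CCC4)ncnc32)[C@H](O)[C@@H]1O` returns only a limit in this assay, > 100000 nM; this is the limit of > 100000 nM in this assay, at which 1 of the 3 values shown sits, not a number. No pair among these three differs in one place, so no single step is measured.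

Compound 4 `CSC[C@@]12C[C@@H]1[C@@H](n1cnc3c(N[C@H](C(C)C)C4CC4)nc(Cl)nc31)[C@H](O)[C@@H]2O` differs from compound 1 as follows: methylsulfanyl in place of azido on a saturated chain carbon bound to a saturated ring carbon. The azido group leaves, methylsulfanyl enters, with no ring either way, one hydrogen-bond acceptor lost and one gained, and no net charge on either side. Among the compounds with values here, the remaining compounds offer no measured step of this kind, so no direction is indicated beyond the scatter; the expected step from compound 1 to compound 4 is no change at the digits printed from compound 1 to compound 4 (within the scatter), essentially none. Compound 4 is accordingly expected to give about 32000 nM in this assay, within a range from 10000 nM to 100000 nM, with some chance of a limit as seen for compound 3.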

Compound 4, half-maximal cytotoxic concentration: 32000 nM
Compound 4: the middle estimate sits on the measured number at the digits printed, and the stated range covers the measured number.
By their numbers in this assay, from the lowest: compounds 2, 1 and 4 (each within the scatter of the next). At a limit, above all of these: compound 3.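

In this assay, within the data shown here, exchanging azido for methylsulfanyl on a saturated chain carbon bound to a saturated ring carbon gives no change at the digits printed from compound 1 to compound 4 (within the scatter), the only step in this set that is read at a single place. Among these compounds, at this place, the read-out therefore does not separate these two groups, something the earlier compounds, none of which differ in one place, could not show. Nothing measured here bears on why the two groups read alike.

This single pair of groups supports no wider rule for the position. Going by these compounds, it remains open whether an amine or a carboxylic acid on the same saturated chain carbon would stay within the scatter of compound 1 or would move the read-out beyond it.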